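The compounds below may be only part of what the source reports. "The series", "measured", "known", "first", "only" and "open" are said of these compounds alone.

Compound 3 `COc1cccc(CNc2ncnc3c2ncn3[C@@H]2O[C@H](CO)[C@@H](O)[C@H]2O)c1` gives no starting number in a functional assay on G-361 cells (Homo sapiens) for antiproliferative activity, with a stated time of 72 h (on this read-out lower numbers stand for stronger inhibition and higher numbers for weaker inhibition), because its entry reads "not determined" (no result reported). Its position therefore has to be judged from its two closest relatives, which share the same core. Compound 1 `OC[C@H]1O[C@@H](n2cnc3c(NCc4cccc(F)c4)ncnc32)[C@H](O)[C@@H]1O` gives > 166000 nM, which is a limit of the assay and not a number. Compound 2 `OC[C@H]1O[C@@H](n2cnc3c(NCc4ccc(Br)cc4)ncnc32)[C@H](O)[C@@H]1O` gives > 166000 nM, which is also a limit.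

Compound 4 `OC[C@H]1O[C@@H](n2cnc3c(NCc4ccc(F)cc4F)ncnc32)[C@H](O)[C@@H]1O` carries 2,4-difluorophenyl in place of 3-methoxyphenyl on a saturated chain carbon bound to a nitrogen on an aromatic ring. The counted difference is 2,4-difluorophenyl in place of 3-methoxyphenyl on a saturated chain carbon bound to a nitrogen on an aromatic ring. Put another way, 3-methoxybenzyl gives way to 2,4-difluorobenzyl.

Among the measured compounds shown here, only one measured step touches this place, and it is a step that the two limits leave unreadable from compound 1 to compound 2. It shows no size, so it cannot be carried over to the new change. For the measured compounds named here, with no number for compound 3, no step of any size or direction can be expected from it to compound 4. The expectation rests instead on (the limit of > 166000 nM in this assay, at which 2 of the 3 values shown sit), and compound 4 is expected to lie near that limit or to be reported only as a limit itself.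

For compound 4, the expected value in this assay is about 150000 nM, with an estimated range from 40000 nM to 170000 nM.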

Compound 4, half-maximal inhibitory concentration: > 166000 nM
Compound 4 gave a limit, no number; the forecaster's own chance of this, stated with the estimate: 65%; middle value at least 1.1-fold (0.04 log units) away from the limit.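

In this assay compound 4 gives > 166000 nM, which is a limit of the assay and not a number. Among the compounds shown here, compound 1 and compound 2 also sit at limits, so no step between any of these three compounds can be read. The compounds shown leave open whether their benzyl groups differ at all in this assay, and where compound 3 stands, as the results rest on a single mark: the limit of > 166000 nM in this assay, at which 3 of the 4 values shown sit.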